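A Further Methoxy on the Core of Compound 3

This account rests on a few compounds, and the source may have more. Where it says the series, first, only, none or still open, it means among the compounds named here.

In a functional assay on MDA-MB-231 cells (Homo sapiens) for antiproliferative activity, read by sulforhodamine B assay, with a stated time of 48 h (on this read-out higher numbers stand for weaker inhibition and lower numbers for stronger inhibition), compound 3 `COc1cc(OC)c2sc(-c3ccc(N/C=C\C(=O)c4ccc(OC)c([N+](=O)[O-])c4)cc3)nc2c1` gives 12900 nM and so sits within the scatter of compound 1 `COc1cc(OC)c2sc(-c3ccc(N/C=C\C(=O)c4ccc(OC)c([N+](=O)[O-])c4)c(C)c3)nc2c1` at 10800 nM and of compound 2 `COc1ccc(C(=O)/C=C\Nc2ccc(-c3nc4cc(OC)c(OC)c(OC)c4s3)cc2C)cc1[N+](=O)[O-]` at 12400 nM on this read-out. Compound 4 `COc1ccc(C(=O)/C=C\Nc2ccc(-c3nc4cc(OC)c(OC)c(OC)c4s3)cc2)cc1[N+](=O)[O-]` differs from compound 3 by methoxy in place of hydrogen on an aromatic carbon in one place, methoxy in place of hydrogen on an aromatic carbon. The same exchange has been measured once and gave a 1.1-fold higher number from compound 1 to compound 2 (0.06 log units; within the scatter) as its result. Among the compounds with values here, the only other measured step, hydrogen in place of methyl on an aromatic carbon, gave a 1.2-fold higher number from compound 1 to compound 3 (0.08 log units; within the scatter) and was equally small. In this assay the expected step is therefore a 1.0-fold higher number from compound 3 to compound 4 (0.02 log units; within the scatter) and thus none beyond the scatter. Compound 4 is estimated at 13500 nM with an expected range of 7500 nM to 24000 nM around that figure.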

Compound 4, half-maximal inhibitory concentration: 17100 nM
Compound 4: the middle estimate sits 1.3-fold (0.10 log units) below what was measured; measured number inside the range.
By their numbers in this assay, from the lowest: compounds 1, 2, 3 and 4 (each within the scatter of the next).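

In this assay, the methoxy entering ortho to two methoxy groups now has a second reading, a 1.3-fold higher number from compound 3 to compound 4 (0.12 log units; within the scatter), and it stays as small as the first: the same change on two cores in this assay, a 1.1-fold higher number (0.06 log units; within the scatter) from compound 1 to compound 2 and a 1.3-fold higher number (0.12 log units; within the scatter) from compound 3 to compound 4, 1.2-fold (0.06 log units) apart, within the scatter of two such steps

Hydrogen in place of methyl also reads the same with that methoxy present, a 1.4-fold higher number from compound 2 to compound 4 (0.14 log units; within the scatter): the same change on two cores in this assay, a 1.2-fold higher number (0.08 log units; within the scatter) from compound 1 to compound 3 and a 1.4-fold higher number (0.14 log units; within the scatter) from compound 2 to compound 4, 1.2-fold (0.06 log units) apart, within the scatter of two such steps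

Across these four compounds, neither exchange moves the number beyond the scatter, whichever core carries it.

Going by these compounds, it remains open whether a different group at this position, such as an amine or a carboxylic acid, would move the number beyond the scatter.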